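Lengthening the chain of compound 3 by four carbons

The source may hold more compounds than are shown below. What is called first, only, known or untested is meant among the compounds shown, and "the series" means these compounds.

Three compounds share one core and differ only in the chain attached to its carbonyl. Compound 1 `O=C(CCc1ccccc1)c1nc2ncccc2o1` gives 18200 nM in an assay on HEK-293T cells for inhibition of diacylglycerol lipase-alpha (Homo sapiens), read by colorimetric assay; on this read-out lower numbers stand for stronger inhibition and higher numbers for weaker inhibition. Compound 3 `CCCCCCCC(=O)c1nc2ncccc2o1` gives 631 nM, and compound 2 `O=C(CCCCCCCCc1ccccc1)c1nc2ncccc2o1` gives 3.63 nM. Compound 3 therefore sits in the middle: the step of a 29-fold lower number from compound 1 to compound 3 (1.46 log units; beyond the scatter) shows that a longer saturated chain pays off, while the step of a 170-fold higher number from compound 2 to compound 3 (2.24 log units; beyond the scatter) shows how much is lost when the far end of the chain is trimmed back.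

Compound 4 `CCCCCCCCCCCC(=O)c1nc2ncccc2o1` has not yet been measured. It differs from compound 3 by butyl in place of hydrogen on a saturated chain carbon, seven bonds along the chain from a carbonyl carbon. Both measured steps point the same way: more chain at this end of the molecule has so far given a lower number, and the change here adds length at exactly the position where compound 2 gained so much. A large step downward is therefore expected in this assay, though smaller than the gain from benzyl, since butyl carries no ring. The expected result for compound 4 is 40 nM, within a range of 8 nM to 200 nM, corresponding to an estimated step of a 16-fold lower number from compound 3 to compound 4 (1.20 log units; beyond the scatter).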

Compound 4, half-maximal inhibitory concentration: 30.9 nM
The estimate for compound 4 lay 1.3-fold (0.11 log units) above the measured number, within the range that was stated.
By their numbers in this assay, from the lowest: compound 2; then compound 4; then compound 3; then compound 1.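

In this assay, adding butyl on a saturated chain carbon, seven bonds along the chain from a carbonyl carbon, gives a 20-fold lower number from compound 3 to compound 4 (1.31 log units; beyond the scatter) as a large step, so a plain chain with no ring can by itself bring a large gain at this position. The end of the chain still matters: propyl in place of phenyl on a saturated chain carbon, eight bonds along the chain from a carbonyl carbon, gives an 8.5-fold higher number from compound 2 to compound 4 (0.93 log units; beyond the scatter) as a modest step, which leaves the phenyl-ended chain of compound 2 ahead. No measurement available here explains either step.

Going by these compounds, whether a still longer unbranched chain would lower the number further or raise it again stays open. So does the effect of ending the chain in an amine or a carboxylic acid instead of phenyl.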